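Enlarging the Amide Group on a Shared Core

The source may report more compounds than this note shows. Statements on the series, on what has been measured and on what is new or still open speak of the compounds shown alone.

compound 1 `CC(=O)N1CC2CC(C1)N2`: 750 nM
compound 2 `CCCC(=O)N1CC2CC(C1)N2`: 300 nM

In an assay on CHO cells for agonist activity at Neuronal acetylcholine receptor; alpha3/alpha6/beta2/beta3 (Homo sapiens), read by FLIPR and calcium flux (a higher number here means that more compound is needed for the effect, a lower number that less compound is needed), compound 1 gives 750 nM, the highest of the two numbers measured. Compound 2 gives 300 nM. For the measured compounds named here, the one step measured between them is a 2.5-fold lower number from compound 1 to compound 2 (0.40 log units; beyond the scatter), a modest change that lies beyond the scatter.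

Compound 3 `O=C(C1CCC1)N1CC2CC(C1)N2` differs from compound 1 by cyclobutyl in place of methyl on a carbonyl carbon. Going by the values given here, the only measured step that bears on this change is a 2.5-fold lower number from compound 1 to compound 2 (0.40 log units; beyond the scatter), in which a larger group on the carbonyl carbon went with a lower number. The change to compound 3 also places a larger group on the carbonyl carbon, so a step of similar size in the same direction is expected, a 3.0-fold lower number from compound 1 to compound 3 (0.48 log units; beyond the scatter). Compound 3 is therefore estimated to give 250 nM in this assay, expected to lie between 100 nM and 700 nM.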

Compound 3, half-maximal effective concentration: 370 nM
Estimate against measurement, compound 3: 1.5-fold (0.17 log units) below; low and high end bracket the measured number.
By their numbers in this assay, from the lowest: compounds 2 and 3 (each within the scatter of the next); then compound 1.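

In this assay, cyclobutyl on the carbonyl carbon gives a 2.0-fold lower number from compound 1 to compound 3 (0.31 log units; beyond the scatter) and so shows that the lower number seen with propyl is not confined to an open chain. The step from propyl to the ring gives a 1.2-fold higher number from compound 2 to compound 3 (0.09 log units; within the scatter) and lies within the scatter, so compound 2 and compound 3 cannot be placed in any order, and in these two compounds the ring makes no measurable difference compared with the chain. No evidence at hand accounts for either step.

The compounds shown leave open whether the number would keep falling with a longer chain such as pentyl or a larger ring such as cyclohexyl. They also do not tell how an aromatic ring such as phenyl, or a chain ending in an amine, would read at this place.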